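The compounds below may be only part of what the source reports. "The series", "measured", "known", "first", "only" and "open" are said of these compounds alone.

Measured so far, in a functional assay on HCT-116 cells (Homo sapiens) for antiproliferative activity, read by MTT assay, with a stated time of 72 h; a higher number here means a weaker inhibitor, a lower number a stronger inhibitor:

- Compound 1 `COc1ccc(-c2cn(C/C=C3\OC(=O)C(OCc4ccccc4)=C3OCc3ccccc3)nn2)cc1` gives only a limit of the assay, > 100000 nM.
- Compound 2 `Cc1ccc(S(=O)(=O)NCc2cn(C[C@H](O)[C@H]3OC(=O)C(OCc4ccccc4)=C3OCc3ccccc3)nn2)cc1` gives 13100 nM.
- Compound 3 `O=C1O[C@H]([C@@H](O)Cn2cc(-c3cc(F)cc(F)c3)nn2)C(OCc2ccccc2)=C1OCc1ccccc1` gives 48200 nM.

For the measured compounds named here, compound 3 thus holds the highest of the two real numbers in this assay; its nearest neighbour is compound 2, and the one step measured, a 3.7-fold higher number from compound 2 to compound 3 (0.57 log units; beyond the scatter), separates them. Compound 1 sits at a limit, (the limit of > 100000 nM in this assay, at which 1 of the 3 values shown sits), so it gives no number to compare.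

Compound 4 `C[Si](C)(C)c1cn(C[C@H](O)[C@H]2OC(=O)C(OCc3ccccc3)=C2OCc2ccccc2)nn1` is the next compound. It differs from compound 3 in one place: a group of 4 heavy atoms (3 carbon, 1 silicon; no ring) in place of a group of 8 heavy atoms (6 carbon, 2 fluorine; one six-membered aromatic ring of carbon only), on an aromatic carbon.

Going by the values given here, only one measured step bears on this, the swap of one aromatic substituent for another from compound 2 to compound 3, which was modest. Here a ring-free group of 4 heavy atoms (3 carbon, 1 silicon) replaces the 3,5-difluorophenyl; no measured step covers such a change, so the direction is open, and a step of modest size in either sense, or none beyond the scatter, is expected: a 1.0-fold higher number from compound 3 to compound 4 (0.02 log units; within the scatter).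

Compound 4 is therefore estimated at 50000 nM in this assay, expected between 15000 nM and 100000 nM.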

Compound 4, half-maximal inhibitory concentration: 31800 nM
Compound 4: the middle estimate sits 1.6-fold (0.20 log units) above what was measured, within the range that was stated.
By their numbers in this assay, from the lowest: compound 2; then compounds 4 and 3 (each within the scatter of the next). At a limit, above all of these: compound 1.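

On the aromatic carbon of the five-membered ring with 3 nitrogen, replacing the 3,5-difluorophenyl with a ring-free group of 4 heavy atoms (3 carbon, 1 silicon) gives no change beyond the scatter in this assay (a 1.5-fold lower number from compound 3 to compound 4 (0.18 log units; within the scatter)). For the compounds shown here, an aromatic ring at this position is therefore not needed to keep this level of activity, something the earlier compounds could not show, while the (((4-methylphenyl)sulfonyl)amino)methyl group still gives the lower number (a 2.4-fold higher number from compound 2 to compound 4 (0.39 log units; beyond the scatter)). Nothing measured here accounts for these differences.

Going by these compounds, whether a primary amine, a carboxylic acid or a longer alkyl chain on this carbon would behave like the silicon group or like the sulfonyl-bearing one remains open. Also open, on these data alone, is whether any group here can bring the number well below those seen so far.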